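A few compounds are considered here, and "the series" means these few. Any claim that something is new, unique, unknown or untested is made for them only; others in the source may bear on it.

Among the compounds with values here, in a functional assay on SNB-75 cells (Homo sapiens) for inhibition, read by sulforhodamine B assay, with a stated time of 48 h, tested at 100 uM (on this read-out lower numbers stand for a stronger effect and higher numbers for a weaker effect at the one concentration tested), compound 2 `COc1cc(Cl)cc(-c2nn(-c3cccc(NC(=O)Nc4ccc(Cl)c(C(F)(F)F)c4)c3)cc2-c2ccncc2)c1` gives -38%, the higher of the two numbers so far, though compound 1 `O=C(Nc1cccc(-n2cc(-c3ccncc3)c(-c3cc(O)cc(Cl)c3)n2)c1)Nc1ccc(Cl)c(C(F)(F)F)c1` at -41% lies within the scatter of it. Within the data shown here, the only measured step, a number 3 percentage points higher from compound 1 to compound 2 (within the scatter), concerns the oxygen substituent and does not touch the carbonyl region, so it does not bear on the change to compound 3 `COc1cc(Cl)cc(-c2nn(-c3cccc(NC(=O)c4cccc(C(F)(F)F)c4)c3)cc2-c2ccncc2)c1`, which is 3-(trifluoromethyl)phenyl in place of (4-chloro-3-(trifluoromethyl)phenyl)amino on a carbonyl carbon. Among the measured compounds shown here, with no measured step to guide it, the estimated step of a number 13 percentage points higher from compound 2 to compound 3 (beyond the scatter) is expected to run toward a weaker effect and beyond the scatter. Compound 3 is therefore expected to give -25%, with a range from -55% to 5%.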

Compound 3, a percentage reported as activity, at one concentration (the size of the read-out at that concentration, not a potency): 49%
The estimate for compound 3 lay 74 percentage points below the measured number; measured number above the stated range.
By their numbers in this assay, from the lowest: compounds 1 and 2 (each within the scatter of the next); then compound 3.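

In this assay, the carbonyl position responds strongly: 3-(trifluoromethyl)phenyl in place of (4-chloro-3-(trifluoromethyl)phenyl)amino gives a number 87 percentage points higher from compound 2 to compound 3 (beyond the scatter), whereas the oxygen substituent gave only a number 3 percentage points higher from compound 1 to compound 2 (within the scatter). This single change removes the amino nitrogen, with its hydrogen-bond donor, and the chlorine together, so their contributions cannot be separated. Nothing available explains the size of this step. Going by these compounds, it remains open whether the nitrogen or the chlorine matters more, and whether a methylene group in place of the amino nitrogen would restore the effect.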